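Bromo for phenyl: expected cytotoxicity of compound 4

This account rests on a few compounds, and the source may have more. Where it says the series, first, only, none or still open, it means among the compounds named here.

Compound 3 `O=C(/C=C/c1ccc([N+](=O)[O-])o1)c1ccc(-c2ccccc2)cc1` is the reference point for this step. In an ADME assay on THP-1 cells (Homo sapiens) for cytotoxicity, read by resazurin assay, with a stated time of 72 h (on this read-out higher numbers stand for lower toxicity in this test and lower numbers for higher toxicity in this test), compound 3 gives 50400 nM, the highest of the two numbers recorded in this assay. Its nearest neighbour is compound 1 `Cc1cccc(C(=O)/C=C/c2ccc([N+](=O)[O-])o2)c1`, which in this assay gives 42100 nM, a gap that sits within the scatter. Compound 2 `CC(C)(C)c1ccc(C(=O)/C=C/c2ccc([N+](=O)[O-])o2)cc1` in this assay gives only a limit, > 50000 nM, and not a number.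

The one single-point step measured among these compounds runs from compound 2 to compound 3, a step that the limit leaves unreadable from compound 2 to compound 3; its size cannot be read because of the limit of > 50000 nM in this assay, at which 1 of the 3 values shown sits. Within the data shown here, no other measured step bears on the change now in question.

Compound 4 `O=C(/C=C/c1ccc([N+](=O)[O-])o1)c1ccc(Br)cc1` differs from compound 3 in one place: bromo in place of phenyl on an aromatic carbon. Among the measured compounds shown here, with the only relevant step unreadable and the two readable numbers in this assay lying within the scatter of each other, nothing in the data points to a step beyond the scatter in either direction. The step from compound 3 to compound 4 is therefore expected to be a 1.1-fold lower number from compound 3 to compound 4 (0.05 log units; within the scatter). Compound 4 in this assay is estimated at 45000 nM, with a range from 20000 nM to 100000 nM.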

Compound 4, half-maximal cytotoxic concentration: 13400 nM
Compound 4: the middle estimate sits 3.4-fold (0.53 log units) above what was measured; measured number below the stated range.
By their numbers in this assay, from the lowest: compound 4; then compounds 1 and 3 (each within the scatter of the next).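

In this assay, among these compounds, bromo in place of phenyl on this aromatic carbon gives a 3.8-fold lower number from compound 3 to compound 4 (0.58 log units; beyond the scatter), the first readable step beyond the scatter and one towards higher toxicity in this test. Bromo in place of tert-butyl on the same carbon points the same way, with an at least 3.7-fold lower number from compound 2 to compound 4 (0.57 log units; beyond the scatter), although this step is read against a limit and gives only a bound on its size, while the step between the tert-butyl and phenyl compounds cannot be read: the limit of > 50000 nM in this assay, at which 1 of the 4 values shown sits. Together the two steps show that the read-out at this position is not indifferent to the group it carries, since two larger groups both stand on the side of lower toxicity in this test relative to bromo, and no compound shown goes against this.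

What the compounds shown leave open is whether this step belongs to bromo itself or would appear with any small group in this place. Chloro, an amine or a carboxylic acid on the same aromatic carbon, each read in this assay, would separate these two readings.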